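A few compounds are considered here, and "the series" means these few. Any claim that something is new, unique, unknown or untested is made for them only; others in the source may bear on it.

Measured so far:
compound 1 `CC(C)N(Cc1cccc(OCCCCCC(=O)O)c1)C(=O)c1ccc(-c2cccc(-c3ccccc3)c2)cc1`: > 26000 nM
compound 2 `CCOC(=O)CCCCCOc1cccc(CN(C(=O)c2ccc(-c3ccc4ccccc4c3)cc2)C(C)C)c1`: > 26000 nM

In an ADME assay on HepG2 cells (Homo sapiens) for cytotoxicity, read by CellTiter-Glo and resazurin assay, with a stated time of 72 h (a lower number here means that less compound is needed, a higher number that more compound is needed for the effect), compound 1 gives only a limit, > 26000 nM. In this assay compound 2 likewise gives only a limit, > 26000 nM. Both values shown sit at the limit of > 26000 nM in this assay, at which 2 of the 2 values shown sit. Compound 3 `CCOC(=O)CCCCCOc1cccc(CN(C(=O)c2ccc(-c3cccc(-c4ccccc4)c3)cc2)C(C)C)c1` differs from compound 2 by 3-phenylphenyl in place of naphthalen-2-yl on an aromatic carbon. For the measured compounds named here, no step between measured compounds is at hand; compound 1 already carries the 3-phenylphenyl group and gives a limit as well. No step beyond the scatter is expected in this assay. Compound 3 is expected at 26000 nM (range 20000 nM to 30000 nM), most likely again only a limit. The expected step is a number no higher from compound 2 to compound 3 (the limit leaves the size open).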

Compound 3, half-maximal effective concentration: > 26000 nM
Compound 3: a limit, no number; the forecaster's own chance of this, stated with the estimate: 90%; the middle value lies on the limit itself.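

In this assay compound 3 gives > 26000 nM, a limit, not a number. The steps from compound 1 and compound 2 to compound 3 cannot be read. The compounds shown leave open where the half-maximal effective concentration of any of them lies.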